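Dihalophenyl versus methoxyphenyl on the enone carbonyl

The source may hold more compounds than are shown below. What is called first, only, known or untested is meant among the compounds shown, and "the series" means these compounds.

Working notes on a pair of pyrazole enones sharing one core, compound 1 `COc1cc(-c2cc(/C=C/C(=O)c3ccc(Cl)c(Cl)c3)[nH]n2)cc(OC)c1OC` and compound 2 `COc1ccc(C(=O)/C=C/c2cc(-c3cc(OC)c(OC)c(OC)c3)n[nH]2)cc1`, with a third member, compound 3 `COc1cc(-c2cc(/C=C/C(=O)c3ccc(F)c(F)c3)[nH]n2)cc(OC)c1OC`, still to be measured. In a functional assay on SF-539 cells (Homo sapiens) for cytotoxicity, read by sulforhodamine B assay, with a stated time of 48 h, tested at 10 uM (a lower number here means a stronger effect, a higher number a weaker effect of the compound at the concentration tested), compound 1 gives 28%, while compound 2 gives -92%. For the measured compounds named here, compound 2 therefore stands lowest of the two numbers so far, its nearest neighbour being compound 1, and the single measured step, a number 120 percentage points lower from compound 1 to compound 2 (beyond the scatter), is large and beyond the scatter.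

Compound 3 differs from compound 2 at the carbonyl carbon: 3,4-difluorophenyl in place of 4-methoxyphenyl on a carbonyl carbon. Going by the values given here, the only step that bears on this change is the one from compound 1 to compound 2, in which a 4-methoxyphenyl displaced a 3,4-dichlorophenyl at the same place and the number fell steeply. Compound 3 reverses that exchange in kind, with a 3,4-difluorophenyl rather than a 3,4-dichlorophenyl entering, so a step upward in this assay is expected, of a size near a number 102 percentage points higher from compound 2 to compound 3 (beyond the scatter), because compound 1 with its dihalophenyl already sits at 28%. Compound 3 is accordingly estimated at 10%, within a range from -40% to 50%.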

Compound 3, a percentage reported as activity, at one concentration (the size of the read-out at that concentration, not a potency): 21%
Compound 3: middle estimate off by 11 percentage points, on the low side; the range from low to high includes it.
By their numbers in this assay, from the lowest: compound 2; then compounds 3 and 1 (each within the scatter of the next).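

In this assay, 3,4-difluorophenyl in place of 4-methoxyphenyl on a carbonyl carbon gives a number 113 percentage points higher from compound 2 to compound 3 (beyond the scatter), so the large gap first seen with 3,4-dichlorophenyl is not confined to that one group. Between the two dihalophenyl compounds, the exchange of 3,4-dichlorophenyl for 3,4-difluorophenyl gives a number 7 percentage points lower from compound 1 to compound 3 (within the scatter), so the choice between these two groups makes no readable difference at this position, and the 4-methoxyphenyl group alone stands apart among the three compounds. Nothing available explains why compound 2 separates from the two dihalophenyl compounds in this way.

The compounds shown place only two kinds of group at this position, a dihalophenyl and a 4-methoxyphenyl, so it remains open whether the low number depends on the methoxy group itself or would also appear with an unsubstituted phenyl, a 4-hydroxyphenyl or a 4-dimethylaminophenyl. Also open, as far as these compounds go, is whether the same separation holds in other cell lines or at other concentrations, since these values come from one cell line at a single concentration.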